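The compounds below may be only part of what the source reports. "The series", "measured", "known", "first", "only" and "open" are said of these compounds alone.

Measured so far:
compound 1 `COc1ccc(Cc2nc(N)c3nn(-c4ccccc4)cc3n2)cc1` gave 38%
compound 2 `Nc1nc(Cc2ccc(O)cc2)nc2cn(-c3ccccc3)nc12` gave 20%
compound 3 `COc1ccc(CCc2nc(N)c3nn(-c4ccccc4)cc3n2)cc1` gave 22%

All three were tested in an assay on CHO cells for displacement of a labelled ligand from adenosine receptor A3 (Homo sapiens), read by scintillation counting, tested at 1 uM; on this read-out lower numbers stand for less inhibition and higher numbers for more inhibition at the one concentration tested (going by the name of the read-out). Compound 1 and compound 2 differ in one place, (hydrogen in place of methyl on an oxygen on an aromatic ring), and this change made the step of a number 18 percentage points lower from compound 1 to compound 2 (beyond the scatter). Compound 3 carries the same methoxyphenyl group as compound 1, but the difference between the two cores is not broken down here; in this assay compound 3 gives a number close to compound 2 and beyond the scatter below compound 1.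

Compound 4 `Nc1nc(CCc2ccc(O)cc2)nc2cn(-c3ccccc3)nc12` has not been measured. For the measured compounds named here, it differs from compound 3 by hydrogen in place of methyl on an oxygen on an aromatic ring, the same change as the one made from compound 1 to compound 2. Because that earlier change made the step of a number 18 percentage points lower from compound 1 to compound 2 (beyond the scatter), a step of similar direction is expected here, a number 14 percentage points lower from compound 3 to compound 4 (beyond the scatter), so compound 4 is estimated at 8%, with a likely range from 0% to 20%.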

Compound 4, a percentage reported as inhibition, at one concentration (the size of the read-out at that concentration, not a potency): 37%
Beside the measured number, compound 4's estimate is 29 percentage points below it; the whole stated range lies below it.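

Replacing methoxy with hydroxy gives a number 15 percentage points higher from compound 3 to compound 4 (beyond the scatter) in this assay, which does not match the earlier step on the other core: the same change on two cores in this assay, a number 18 percentage points lower (beyond the scatter) from compound 1 to compound 2 and a number 15 percentage points higher (beyond the scatter) from compound 3 to compound 4, 33 percentage points apart, beyond the scatter of two such steps. With the hydroxy group kept, 4-hydroxybenzyl in place of 4-hydroxyphenyl gives a number 17 percentage points higher from compound 2 to compound 4 (beyond the scatter), and 4-hydroxybenzyl in place of 4-methoxyphenyl gives a number 1 percentage points lower from compound 1 to compound 4 (within the scatter). So in these two pairs the result of the change depends on the core carrying it, but the data do not show why, and two pairs set no rule for other cores.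

The compounds shown leave open how an ethoxy group or an amine would read in place of the methoxy or hydroxy group. They also leave open what a longer chain to the aromatic ring would do.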